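Amide series: cytotoxicity limits and a vinyl analogue

The source may hold more compounds than are shown below. What is called first, only, known or untested is meant among the compounds shown, and "the series" means these compounds.

Compound 1 `C=C1CCC(c2csc(/C=C(\C)C(N)=O)c2)CC1` — in an ADME assay on NIH3T3 cells (Mus musculus) for cytotoxicity, read by CCK-8 assay, with a stated time of 24 h (on this read-out lower numbers stand for stronger inhibition and higher numbers for weaker inhibition), compound 1 sits at the limit > 50000 nM.
Compound 2 `C/C(=C\c1cccc(-c2ccccc2)c1)C(N)=O` — in this assay compound 2 sits at the limit > 50000 nM.
Compound 3 `C/C(=C\c1cc(-c2ccc(C#N)cc2)cs1)C(N)=O` — in this assay compound 3 sits at the limit > 50000 nM.

Compound 3 shows only a limit, not a number, and the two other values shown are limits as well. Among the compounds with values here, every value so far rests at the limit of > 50000 nM in this assay, at which 3 of the 3 values shown sit. Within the data shown here, no step between measured compounds is available. Compound 4 `C=Cc1ccc(-c2csc(/C=C(\C)C(N)=O)c2)cc1` differs from compound 3 by vinyl in place of cyano on an aromatic carbon. With all measured values at one limit, the step of a number no higher from compound 3 to compound 4 (the limit leaves the size open) is expected to stay within the scatter, with no direction favoured. Compound 4 is therefore estimated to read 50000 nM, within 20000 nM to 150000 nM, most probably again as a limit.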

Compound 4, half-maximal inhibitory concentration: > 50000 nM
Compound 4 ended at the assay's limit (the forecaster's own chance of this, stated with the estimate: 85%); the middle value lies on the limit itself.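

No step can be read from compound 3 to compound 4, since both values are limits: the limit of > 50000 nM in this assay, at which 4 of the 4 values shown sit.

The compounds shown leave open how far any of them lies from that limit in this assay, and which structural change would give a numerical value.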